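A few compounds are considered here, and "the series" means these few. Any claim that something is new, unique, unknown or untested is made for them only; others in the source may bear on it.

Measured so far in an ADME assay on HEK293 cells (Homo sapiens) for inhibition, read by CellTiter-Glo, with a stated time of 96 h, tested at 100 uM; a lower number here means less inhibition, a higher number more inhibition at the concentration tested (going by the name of the read-out):
compound 1, `CC(C)(CO)[C@H](O)C(=O)N/C=C/C(=O)OCc1ccccc1`, gives -6%
compound 2, `CC(C)(CO)[C@@H](O)C(=O)N/C=C\C(=O)OCc1ccccc1`, gives 7%
compound 3, `CCOC(=O)/C=C\NC(=O)[C@@H](O)C(C)(C)CO`, gives -6%

Compound 3 stands level with compound 1 at the digits shown, the two together the lowest of the three numbers; compound 2 sits higher, a number 13 percentage points higher from compound 1 to compound 2 (beyond the scatter), a step that rests on the fact that compounds 1 and 2 differ only in the configuration as drawn alone.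

Compound 4, `CC(C)(CO)[C@H](O)C(=O)N/C=C\C(=O)OCc1ccccc1`, differs from compound 3 in one place: phenyl in place of methyl on a saturated chain carbon bound to an oxygen next to a carbonyl group. Cut one bond further out, the same difference reads ethyl to benzyl. For the measured compounds named here, no measured step touches the ester side; the only step measured concerns configuration and says nothing about a larger group on the saturated chain carbon bound to an oxygen next to a carbonyl group. Compounds 1 and 2 already carry the benzyl ester and show low numbers, so no step beyond the scatter is expected, a number 2 percentage points higher from compound 3 to compound 4 (within the scatter). Compound 4 is therefore estimated at -4%, between -18% and 10%.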

Compound 4, a percentage reported as inhibition, at one concentration (the size of the read-out at that concentration, not a potency): -7%
The estimate for compound 4 lay 3 percentage points above the measured number, within the range that was stated.
By their numbers in this assay, from the lowest: compounds 4, 1 and 3 (each within the scatter of the next); then compound 2.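

In this assay, phenyl in place of methyl on a saturated chain carbon bound to an oxygen next to a carbonyl group gives a number 1 percentage points lower from compound 3 to compound 4 (within the scatter). Changing the double bond alone from E to Z gives a number 1 percentage points lower from compound 1 to compound 4 (within the scatter), while changing the stereocentre alone from R to S gives a number 14 percentage points lower from compound 2 to compound 4 (beyond the scatter). Among compounds 1, 2 and 4, the difference therefore follows the stereocentre and not the double bond: the fact that compounds 2 and 4 differ only in the configuration as drawn

From the compounds shown here alone, whether the stereocentre has the same effect with an ethyl group remains open. So does the outcome of placing an amine or a carboxylic acid in place of phenyl.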